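A few compounds are considered here, and "the series" means these few. Any claim that something is new, unique, unknown or untested is made for them only; others in the source may bear on it.

Measured so far in a functional assay on MCF7 cells (Homo sapiens) for antiproliferative activity, read by sulforhodamine B assay, with a stated time of 48 h; a lower number here means a stronger inhibitor, a higher number a weaker inhibitor:
compound 1, `CCCC(=O)Nc1ccc(S(=O)(=O)Oc2ccccc2I)cc1`, 9700 nM
compound 2, `CC(C)C(=O)Nc1ccc(S(=O)(=O)Oc2ccccc2I)cc1`, 8100 nM
compound 3, `CC(C)(C)C(=O)Nc1ccc(S(=O)(=O)Oc2ccccc2I)cc1`, 6600 nM

Compound 3 carries the lowest number of the three, yet the steps of a 1.5-fold lower number from compound 1 to compound 3 (0.17 log units; within the scatter) and a 1.2-fold lower number from compound 2 to compound 3 (0.09 log units; within the scatter) both sit within the scatter, as does a 1.2-fold lower number from compound 1 to compound 2 (0.08 log units; within the scatter), so nothing separates the three on this assay.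

Compound 4, `CCNC(=O)Nc1ccc(S(=O)(=O)Oc2ccccc2I)cc1`, differs from compound 3 in one place: ethylamino in place of tert-butyl on a carbonyl carbon. The three measured steps only reshape the alkyl on the carbonyl carbon and never bring a nitrogen into that position, so they bear on this change only loosely, and all were flat. Going by the values given here, with no closer precedent, the step is expected to stay within the scatter: a 1.4-fold higher number from compound 3 to compound 4 (0.13 log units; within the scatter). Compound 4 is therefore estimated at 9000 nM, with a range of 3000 nM to 30000 nM.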

Compound 4, half-maximal inhibitory concentration: 1100 nM
The estimate for compound 4 lay 8.2-fold (0.91 log units) above the measured number; the whole stated range lies above it.
By their numbers in this assay, from the lowest: compound 4; then compounds 3, 2 and 1 (each within the scatter of the next).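

In this assay, the substituent on the carbonyl carbon proves sensitive after all: reshaping the alkyl group left the three alkyl compounds inseparable, whereas ethylamino in place of tert-butyl gives a 6.0-fold lower number from compound 3 to compound 4 (0.78 log units; beyond the scatter). The change holds against the other two alkyl groups, with ethylamino in place of isopropyl giving a 7.4-fold lower number from compound 2 to compound 4 (0.87 log units; beyond the scatter) and ethylamino in place of propyl giving an 8.8-fold lower number from compound 1 to compound 4 (0.95 log units; beyond the scatter). No measured evidence accounts for this shift.

Open, from the compounds shown here alone, is whether the shift depends on the nitrogen alone or also on the ethyl chain. Methylamino, propylamino or dimethylamino on the same carbonyl carbon would address this.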